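Trifluoromethyl added to the phenyl of compound 3

A few compounds are considered here, and "the series" means these few. Any claim that something is new, unique, unknown or untested is made for them only; others in the source may bear on it.

Measured compounds:
compound 1, `NS(=O)(=O)c1ccc(Nc2ncc(/N=C/c3ccc(C(F)(F)F)cc3)c(NC3CCCC3)n2)cc1`, > 100000 nM
compound 2, `CC(C)Nc1nc(Nc2ccc(N3CCN(C)CC3)cc2)ncc1/N=C/c1ccc(C(F)(F)F)cc1`, > 100000 nM
compound 3, `CC(C)Nc1nc(Nc2ccc(S(N)(=O)=O)cc2)ncc1/N=C/c1ccccc1`, 98200 nM

Three compounds share a core and were tested in a functional assay on HT-29 cells (Homo sapiens) for antiproliferative activity, read by MTT assay; on this read-out lower numbers stand for stronger inhibition and higher numbers for weaker inhibition. Compound 1 `NS(=O)(=O)c1ccc(Nc2ncc(/N=C/c3ccc(C(F)(F)F)cc3)c(NC3CCCC3)n2)cc1` reaches only a limit of the assay, > 100000 nM, not a number. Compound 2 `CC(C)Nc1nc(Nc2ccc(N3CCN(C)CC3)cc2)ncc1/N=C/c1ccc(C(F)(F)F)cc1` likewise gives only a limit, > 100000 nM. For the measured compounds named here, compound 3 `CC(C)Nc1nc(Nc2ccc(S(N)(=O)=O)cc2)ncc1/N=C/c1ccccc1` is the one compound with a measured number, 98200 nM. That number for compound 3 lies close to where the other two sit, because of the limit of > 100000 nM in this assay, at which 2 of the 3 values shown sit.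

Compound 4 `CC(C)Nc1nc(Nc2ccc(S(N)(=O)=O)cc2)ncc1/N=C/c1ccc(C(F)(F)F)cc1` has not been measured yet. It differs from compound 3 in one place: trifluoromethyl in place of hydrogen on an aromatic carbon. Going by the values given here, compounds 1 and 2 also carry a trifluoromethyl group on their phenyl, though they differ from compound 3 in other places as well, so no clean step is available. With compound 3 already near the limit, the step from compound 3 to compound 4 is expected to be small, a 1.2-fold higher number from compound 3 to compound 4 (0.09 log units; within the scatter), and most likely not beyond the scatter. Compound 4 is therefore estimated at 120000 nM, with a range from 50000 nM to 300000 nM, and a good chance that this assay reports only a limit.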

Compound 4, half-maximal inhibitory concentration: > 100000 nM
Compound 4: a limit, no number (the forecaster's own chance of this, stated with the estimate: 60%); the middle value lies beyond the limit too.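

In this assay, the change from hydrogen to trifluoromethyl on the phenyl is the first single-place comparison among these compounds, and it reads as an at least 1.0-fold higher number from compound 3 to compound 4 (0.00 log units; that floor lies within the scatter). Trifluoromethyl at this place therefore does not bring the compound into a clearly measurable range, and the true size of the step stays hidden because the read-out stops at the assay's limit: the limit of > 100000 nM in this assay, at which 3 of the 4 values shown sit. The steps linking compound 4 to compound 1 and to compound 2 cannot be read, as both ends of each are limits.

On these data alone, whether another group at this place, such as an amine, a carboxylic acid or a methoxy group, would give a clearly lower number remains open. Also open, as far as these compounds go, is whether trifluoromethyl would make any difference on a core with a number well clear of the limit.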